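A few compounds are considered here, and "the series" means these few. Any claim that something is new, unique, unknown or untested is made for them only; others in the source may bear on it.

Measured so far in a functional assay on cells for antagonist activity at Free fatty acid receptor 1 (Homo sapiens), read by TR-FRET and inositol phosphate accumulation, with a stated time of 2 h; on this read-out higher numbers stand for weaker inhibition and lower numbers for stronger inhibition:

- compound 1, `Cc1cc(COc2cccc(F)c2)nc(-c2ccccn2)n1`: 794 nM
- compound 2, `Cc1cc(COc2ccc(F)c(F)c2)nc(-c2ccccn2)n1`: 501 nM
- compound 3, `Cc1cc(COc2cc(F)c(F)cc2F)nc(-c2ccccn2)n1`: 398 nM

Compound 2 sits second highest of the three numbers. Its nearest neighbour is compound 3, with a 1.3-fold lower number from compound 2 to compound 3 (0.10 log units; within the scatter); the furthest is compound 1, with a 1.6-fold lower number from compound 1 to compound 2 (0.20 log units; within the scatter). Both steps lie within the scatter, so the three compounds cannot be ordered on these numbers.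

Compound 4, `Cc1cc(COc2cc(F)c(F)c(F)c2)nc(-c2ccccn2)n1`, is the next fluorinated variant and has not yet been measured in this assay. From compound 2 it differs by fluoro in place of hydrogen on an aromatic carbon.

Within the data shown here, two measured steps bear on this change, each being a fluoro entering in place of hydrogen on the same aromatic ring: a 1.6-fold lower number from compound 1 to compound 2 (0.20 log units; within the scatter) and a 1.3-fold lower number from compound 2 to compound 3 (0.10 log units; within the scatter). Neither exceeds the scatter, and there is no evidence here that a further fluoro on this ring moves the number in a way that would be detected. In line with the two measured steps, the step that is expected for compound 4 in this assay is a 1.3-fold lower number from compound 2 to compound 4 (0.10 log units; within the scatter).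

Compound 4 is expected to give about 400 nM in this assay, within a range of 200 nM to 900 nM.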

Compound 4, half-maximal inhibitory concentration: 398 nM
Compound 4: the middle estimate sits 1.0-fold (0.00 log units) above what was measured, and the stated range covers the measured number.
By their numbers in this assay, from the lowest: compounds 3, 4, 2 and 1 (each within the scatter of the next).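

In this assay the step of a 1.3-fold lower number from compound 2 to compound 4 (0.10 log units; within the scatter) shows that a fluoro can enter on an aromatic carbon ortho to a fluoro group, meta to a fluoro group and meta to a large group without the number leaving the scatter around compound 2. Among these compounds, this position was not covered by the earlier compounds, and the step of a 1.3-fold lower number from compound 2 to compound 3 (0.10 log units; within the scatter) also stays within the scatter, so neither of the two placements of a further fluoro on compound 2 gives a detectable change on this read-out. Nothing available bears on why the number holds at this position.

Every step shown exchanges hydrogen for fluoro, so it remains open whether a chloro, a methoxy group, an amine or a carboxylic acid at this position would move the number beyond the scatter. The shared core is also the same throughout, which leaves open what a longer chain in place of its methyl group would do.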